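The source may report more compounds than this note shows. Statements on the series, on what has been measured and on what is new or still open speak of the compounds shown alone.

Compound 3, `COc1ccc(/C=C/C(=O)Nc2cc3c(Nc4ccc(F)c(Cl)c4)ncnc3cc2O[C@H]2CCOC2)c(OC)c1OC`, gives 7670 nM in a functional assay on PC-3 cells (Homo sapiens) for cytotoxicity, read by MTT assay, with a stated time of 72 h (a lower number here means a stronger inhibitor, a higher number a weaker inhibitor), the lowest of the three numbers measured. Compound 2, `COc1cc(/C=C/C(=O)Nc2cc3c(Nc4ccc(F)c(Cl)c4)ncnc3cc2O[C@H]2CCOC2)cc(OC)c1`, gives 25600 nM, and compound 1, `COc1ccc(/C=C/C(=O)Nc2cc3c(Nc4ccc(F)c(Cl)c4)ncnc3cc2OC)c(OC)c1`, gives 38500 nM. Among the measured compounds shown here, the one step measured within this set, a 3.3-fold lower number from compound 2 to compound 3 (0.52 log units; beyond the scatter), shows that the arrangement of methoxy groups on the cinnamoyl ring moves the number by a modest but real amount. Compound 4, `COc1ccc(/C=C/C(=O)Nc2cc3c(Nc4ccc(F)c(Cl)c4)ncnc3cc2O[C@H]2CCOC2)c(OC)c1`, differs from compound 3 by hydrogen in place of methoxy on an aromatic carbon. Compound 1 carries the same 2,4-dimethoxyphenyl as compound 4 but differs from it elsewhere, so its value only hints at the direction. For the measured compounds named here, since compound 3 stands lowest and the one relevant step, a 3.3-fold lower number from compound 2 to compound 3 (0.52 log units; beyond the scatter), rewarded the trimethoxy pattern, the removal of a methoxy is expected to raise the number somewhat, with a 2.0-fold higher number from compound 3 to compound 4 (0.29 log units; within the scatter) expected. Compound 4 is therefore estimated at 15000 nM in this assay, in a range from 6000 nM to 40000 nM.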

Compound 4, half-maximal inhibitory concentration: 2760 nM
The estimate for compound 4 lay 5.4-fold (0.74 log units) above the measured number; measured number below the stated range.
By their numbers in this assay, from the lowest: compound 4; then compound 3; then compounds 2 and 1 (each within the scatter of the next).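

Hydrogen in place of methoxy on an aromatic carbon gave a 2.8-fold lower number from compound 3 to compound 4 (0.44 log units; beyond the scatter) in this assay and so the third methoxy group of the 2,3,4-trimethoxyphenyl is not needed for the lower number. With two methoxy groups on the ring in both compounds, their placement alone accounts for a 9.3-fold lower number from compound 2 to compound 4 (0.97 log units; beyond the scatter) and this shows that the 2,4-dimethoxyphenyl is the best of the three ring patterns here. The other change, oxolan-3-yl in place of methyl on an oxygen on an aromatic ring, gave a 14-fold lower number from compound 1 to compound 4 (1.14 log units; beyond the scatter) and is the largest of these steps, so this second place moves the number at least as much as the ring does.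

The compounds shown leave open whether a single methoxy group, a fluorine or an amine on this ring would keep the number this low. No measurement given here explains any of these steps.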